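This account rests on a few compounds, and the source may have more. Where it says the series, first, only, none or still open, it means among the compounds named here.

Within the data shown here, compound 3 `C=CCOc1ccc2c(=O)c(-c3ccc(O)cc3)coc2c1` sits second highest of the three numbers so far in a functional assay on mitochondria (Cricetulus griseus) for inhibition of Monoamine oxidase (Homo sapiens), tested at 0.9 uM (on this read-out lower numbers stand for a weaker effect and higher numbers for a stronger effect at the one concentration tested), where compound 3 gives 68.8%. Compound 1 `CCOc1ccc2c(=O)c(-c3ccc(O)cc3)coc2c1` gives 86.9%, and compound 2 `O=c1c(-c2ccc(O)cc2)coc2cc(OCCCBr)ccc12` gives 67.7%. Both changes made at the chain on the aromatic oxygen cost inhibition: a number 19.2 percentage points lower from compound 1 to compound 2 (beyond the scatter) and a number 18.1 percentage points lower from compound 1 to compound 3 (beyond the scatter), whereas a number 1.1 percentage points higher from compound 2 to compound 3 (within the scatter), so the two altered chains cannot be told apart.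

Compound 4 `O=c1c(-c2ccc(O)cc2)coc2cc(OCC(O)CO)ccc12` carries the next change at the same place: 1,2-dihydroxyethyl in place of vinyl on a saturated chain carbon bound to an oxygen on an aromatic ring. Among the measured compounds shown here, no measured step swaps a chain end for a 1,2-dihydroxyethyl group, so the steps bearing on it are only those above, which show a modest loss the first time the chain is altered and no further change between two altered chains. The step expected in this assay is therefore small to modest and downward, a number 10.8 percentage points lower from compound 3 to compound 4 (beyond the scatter), with the possibility of none beyond the scatter. Compound 4 is estimated at 58%, in the range 38% to 76%.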

Compound 4, a percentage reported as inhibition, at one concentration (the size of the read-out at that concentration, not a potency): 63.8%
Compound 4: the middle estimate sits 5.8 percentage points below what was measured; the range from low to high includes it.
By their numbers in this assay, from the lowest: compounds 4, 2 and 3 (each within the scatter of the next); then compound 1.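

In this assay the 2,3-dihydroxypropoxy chain, with the hydrogen-bond donors and acceptors that the allyloxy chain lacks, cannot be told apart from the two altered chains already seen: a number 5 percentage points lower from compound 3 to compound 4 (within the scatter) and a number 3.9 percentage points lower from compound 2 to compound 4 (within the scatter) both leave it level with them. Against the chain of compound 1 the loss remains, with a number 23.1 percentage points lower from compound 1 to compound 4 (beyond the scatter) as the step, so compounds 2, 3 and 4 now form one group despite carrying three different chain ends. No measurement shown here accounts for this shared level.

From the compounds shown here alone, whether a chain end such as an amine or a carboxylic acid would stay in this group or return to the level of compound 1 remains open. So does the effect of a plain propyl chain, which would separate chain length from the groups at its end.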